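Replacing 2-nitrophenyl with pyridin-2-yl

The source may report more compounds than this note shows. Statements on the series, on what has been measured and on what is new or still open speak of the compounds shown alone.

compound 1 `Nc1nc(N)c2cc(CSC(=S)N3CCN(c4ccccc4)CC3)ccc2n1`: 2840 nM
compound 2 `Nc1nc(N)c2cc(CSC(=S)N3CCN(c4ccc([N+](=O)[O-])cc4)CC3)ccc2n1`: 1660 nM
compound 3 `Nc1nc(N)c2cc(CSC(=S)N3CCN(c4ccccc4[N+](=O)[O-])CC3)ccc2n1`: 4880 nM

All three were tested in a functional assay on HeLa cells (Homo sapiens) for antiproliferative activity, read by MTT assay, with a stated time of 72 h; a lower number here means a stronger inhibitor, a higher number a weaker inhibitor. Compound 3 cannot be separated from compound 1, with a 1.7-fold higher number from compound 1 to compound 3 (0.24 log units; within the scatter), but it stands apart from compound 2, with a 2.9-fold higher number from compound 2 to compound 3 (0.47 log units; beyond the scatter), a modest step beyond the scatter. Compound 4 `Nc1nc(N)c2cc(CSC(=S)N3CCN(c4ccccn4)CC3)ccc2n1` carries pyridin-2-yl in place of 2-nitrophenyl on an amine nitrogen in a ring. Within the data shown here, no measured step makes this exact exchange. The nearest evidence is the pair of nitro steps, a 1.7-fold lower number from compound 1 to compound 2 (0.23 log units; within the scatter) and a 1.7-fold higher number from compound 1 to compound 3 (0.24 log units; within the scatter), both within the scatter. Only a small change is therefore expected in this assay, towards a lower number if any. The expected step is a 1.7-fold lower number from compound 3 to compound 4 (0.24 log units; within the scatter). For compound 4 the estimated value is 2800 nM, with an expected range from 1300 nM to 6000 nM.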

Compound 4, half-maximal inhibitory concentration: 5090 nM
For compound 4 the middle estimate is 1.8-fold (0.26 log units) below the measured one, within the range that was stated.
By their numbers in this assay, from the lowest: compounds 2, 1, 3 and 4 (each within the scatter of the next, the first and the last beyond it).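

In this assay, pyridin-2-yl on this amine nitrogen could not be told apart from 2-nitrophenyl (a 1.0-fold higher number from compound 3 to compound 4 (0.02 log units; within the scatter)) or from phenyl (a 1.8-fold higher number from compound 1 to compound 4 (0.25 log units; within the scatter)). So the six-membered aromatic ring with a hetero atom fits this position as well as the carbon-only rings of compound 1 and compound 3, and only compound 2 stands apart (a 3.1-fold higher number from compound 2 to compound 4 (0.49 log units; beyond the scatter)). Nothing measured here explains this.

On these data alone, what an amine or a carboxylic acid on the phenyl ring would do remains open. So does whether any group on this nitrogen can give a lower number than the 4-nitrophenyl of compound 2.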